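Pyrazolyl in Place of Phenyl, Judged from Three Limits

The source may report more compounds than this note shows. Statements on the series, on what has been measured and on what is new or still open speak of the compounds shown alone.

Compound 2 `O=c1nc(-c2ccccc2)c2cc(-c3ccccc3)ccc2[nH]1` was tested in an ADME assay on L6 cells (Rattus norvegicus) for cytotoxicity, read by fluorescence and resazurin assay, with a stated time of 72 h; a lower number here means that less compound is needed, a higher number that more compound is needed for the effect. In this assay compound 2 gives > 50000 nM, which is a limit of the assay rather than a number. Compound 1 `O=c1nc(-c2ccccc2)c2cc(-c3cccnc3)ccc2[nH]1` gives > 50000 nM in this assay, again a limit. Compound 3 `Cn1cc(-c2ccc3[nH]c(=O)nc(-c4ccccc4)c3c2)cn1` gives > 50000 nM in this assay, also a limit. Thus (the limit of > 50000 nM in this assay, at which 3 of the 3 values shown sit). Compound 4 `Cn1nccc1-c1ccc2[nH]c(=O)nc(-c3ccccc3)c2c1` is not yet measured and differs from compound 2 by 1-methyl-1H-pyrazol-5-yl in place of phenyl on an aromatic carbon. The nearest measured step is a step that the two limits leave unreadable from compound 2 to compound 3; the steps a step that the two limits leave unreadable from compound 1 to compound 2 and a step that the two limits leave unreadable from compound 1 to compound 3 are equally unreadable. No size or direction can be read, so no step beyond the scatter is expected. Compound 4 is estimated at 60000 nM, with a range from 20000 nM to 200000 nM, most likely again reported only as a limit. The expected step is a step that the limit leaves unreadable from compound 2 to compound 4.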

Compound 4, half-maximal effective concentration: > 50000 nM
Compound 4 gave a limit, no number (the forecaster's own chance of this, stated with the estimate: 85%); the middle value lies beyond the limit too.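

No step can be read among compound 1, compound 2, compound 3 and compound 4, because all four stop at the same limit: the limit of > 50000 nM in this assay, at which 4 of the 4 values shown sit.

From the compounds shown here alone, whether any of these groups on the shared core truly differ in this assay stays open.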